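Benzylsulfanyl variation in a cytotoxicity series

The source may hold more compounds than are shown below. What is called first, only, known or untested is meant among the compounds shown, and "the series" means these compounds.

Measured compounds:
compound 1, `Cc1cc(S(=O)(=O)/N=C(\N)n2nccc2-c2ccccc2)c(SCc2ccc(C(F)(F)F)cc2)cc1Cl`, 17000 nM
compound 2, `Cc1cc(S(=O)(=O)/N=C(\N)n2nccc2-c2ccccc2)c(SCc2ccccc2C)cc1Cl`, 17000 nM

Both compounds were tested in a functional assay on HeLa cells (Homo sapiens) for cytotoxicity, read by MTT assay, with a stated time of 72 h; a lower number here means a stronger inhibitor, a higher number a weaker inhibitor. In this assay compound 1 gives 17000 nM, and compound 2 gives 17000 nM. Among the compounds with values here, the one measured step, no change at the digits printed from compound 1 to compound 2 (within the scatter), shows that exchanging the group on the saturated chain carbon bound to a sulfur left the read-out where it was. Compound 2 therefore stands level with compound 1, and nothing in these two numbers separates them.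

Compound 3, `Cc1cc(S(=O)(=O)/N=C(\N)n2nccc2-c2ccccc2)c(SCc2cccc(C(F)(F)F)c2)cc1Cl`, has not been measured. It differs from compound 2 in one place: 3-(trifluoromethyl)phenyl in place of 2-methylphenyl on a saturated chain carbon bound to a sulfur. The entering group carries the same trifluoromethyl substituent found in compound 1, now as 3-(trifluoromethyl)phenyl rather than 4-(trifluoromethyl)phenyl. Within the data shown here, the only step that bears on this change is no change at the digits printed from compound 1 to compound 2 (within the scatter), and it was flat. On that basis the expected step of no change at the digits printed from compound 2 to compound 3 (within the scatter) is none beyond the scatter. Compound 3 is accordingly estimated at 17000 nM in this assay, with a range from 8000 nM to 36000 nM.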

Compound 3, half-maximal inhibitory concentration: 19000 nM
Beside the measured number, compound 3's estimate is 1.1-fold (0.05 log units) below it; the range from low to high includes it.
By their numbers in this assay, from the lowest: compounds 1, 2 and 3 (each within the scatter of the next).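

In this assay, 3-(trifluoromethyl)phenyl in place of 2-methylphenyl on a saturated chain carbon bound to a sulfur gives a 1.1-fold higher number from compound 2 to compound 3 (0.05 log units; within the scatter), so this place tolerates an entering group of 10 heavy atoms, including 3 fluorine, where the leaving group has 7 carbon atoms, with the read-out staying inside the scatter. The earlier pair changed both the substituent and its ring position at once, whereas 3-(trifluoromethyl)phenyl in place of 4-(trifluoromethyl)phenyl gives a 1.1-fold higher number from compound 1 to compound 3 (0.05 log units; within the scatter) and isolates the position of the trifluoromethyl group, which this assay does not resolve among these compounds. No measurement at hand offers an explanation for this flat read-out.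

From the compounds shown here alone, all three compounds keep a substituted phenyl ring at this place, so the effect of an amine, a carboxylic acid or a longer chain there remains open. Also open, going by these compounds, is whether a 2-(trifluoromethyl)phenyl group would fit the same flat picture, and whether any change at this place could separate compounds when the rest of the shared core is held constant.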